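Closing the chain: indanyl for phenylethyl at the amine

This account rests on a few compounds, and the source may have more. Where it says the series, first, only, none or still open, it means among the compounds named here.

Measured so far:
compound 1 `c1ccc2c(c1)CCC2NC1CCN(CCCc2c[nH]c3ccc(-n4cnnc4)cc23)CC1` — 8.9 nM
compound 2 `CN(Cc1ccccc1)CC1CCN(CCCc2c[nH]c3ccc(-n4cnnc4)cc23)CC1` — 0.9 nM
compound 3 `C[C@H](NCC1CCN(CCCc2c[nH]c3ccc(-n4cnnc4)cc23)CC1)c1ccccc1` — 4.4 nM

In an assay on CHO cells for displacement of a labelled ligand from 5-hydroxytryptamine receptor 1D (Homo sapiens) (on this read-out higher numbers stand for weaker inhibition and lower numbers for stronger inhibition), compound 3 gives 4.4 nM and stands second highest of the three numbers, with compound 1 nearest and compound 2 furthest. Compound 4 `c1ccc2c(c1)CCC2NCC1CCN(CCCc2c[nH]c3ccc(-n4cnnc4)cc23)CC1` differs from compound 3 by 2,3-dihydro-1H-inden-1-yl in place of 1-phenylethyl on an amine nitrogen. Within the data shown here, no measured step makes this change alone: compound 1 carries the same indenyl group but joined to the ring carbon directly, and the step of a 2.0-fold lower number from compound 1 to compound 3 (0.31 log units; beyond the scatter) mixes that linker change with the group swap. The steps of a 9.9-fold lower number from compound 1 to compound 2 (1.00 log units; beyond the scatter) and a 4.9-fold higher number from compound 2 to compound 3 (0.69 log units; beyond the scatter) concern the amine substituent on the same chain and were modest. A small step is therefore expected, a 1.1-fold higher number from compound 3 to compound 4 (0.06 log units; within the scatter), with a number for compound 4 estimated at 5 nM and a range from 1.5 nM to 15 nM.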

Compound 4, half-maximal inhibitory concentration: 1.1 nM
Beside the measured number, compound 4's estimate is 4.5-fold (0.66 log units) above it, and the stated range ends above it.
By their numbers in this assay, from the lowest: compounds 2 and 4 (each within the scatter of the next); then compound 3; then compound 1.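

In this assay, 2,3-dihydro-1H-inden-1-yl in place of 1-phenylethyl on the amine nitrogen gives a 4.0-fold lower number from compound 3 to compound 4 (0.60 log units; beyond the scatter), so this swap can now be read alone, with the linker unchanged. The added linker carbon can also be read alone, with an 8.1-fold lower number from compound 1 to compound 4 (0.91 log units; beyond the scatter), while a 1.2-fold higher number from compound 2 to compound 4 (0.09 log units; within the scatter) leaves those two compounds within the scatter of each other. No evidence is available to explain these steps.

On these data alone, whether a fluorine or methoxy group on the six-membered aromatic ring of 2,3-dihydro-1H-inden-1-yl would keep this level remains open. So does the effect of a defined stereocentre in that group.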